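Compound 3 and the 2-chlorophenyl swap

The source may hold more compounds than are shown below. What is called first, only, known or untested is meant among the compounds shown, and "the series" means these compounds.

In a functional assay on K562 cells (Homo sapiens) for antiproliferative activity, read by MTT assay, with a stated time of 48 h (on this read-out lower numbers stand for stronger inhibition and higher numbers for weaker inhibition), compound 1 `COc1ccc(Nc2nc(Nc3cnn(CCCCCCC(=O)NO)c3)ncc2Cl)cc1` gives 620 nM, compound 2 `O=C(CCCCCCn1cc(Nc2ncc(Cl)c(Nc3ccc(F)cc3)n2)cn1)NO` gives 500 nM and compound 3 `O=C(CCCCCn1cc(Nc2ncc(Cl)c(Nc3ccc(F)cc3)n2)cn1)NO` gives 420 nM. Compound 3 therefore lies within the scatter of both other compounds. Compound 4 `O=C(CCCCCn1cc(Nc2ncc(Cl)c(Nc3ccccc3Cl)n2)cn1)NO` carries 2-chlorophenyl in place of 4-fluorophenyl on a nitrogen on an aromatic ring. Among the compounds with values here, the only measured change on this aryl group, a 1.2-fold lower number from compound 1 to compound 2 (0.09 log units; within the scatter), stayed within the scatter, as did the chain change, a 1.2-fold lower number from compound 2 to compound 3 (0.08 log units; within the scatter). Within the data shown here, no measured compound carries 2-chlorophenyl, so the evidence is indirect, and no shift beyond the scatter is expected. The estimated step is a 1.1-fold higher number from compound 3 to compound 4 (0.03 log units; within the scatter). For compound 4 the expected value is 450 nM, with an estimated range of 180 nM to 1200 nM.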

Compound 4, half-maximal inhibitory concentration: 1810 nM
The estimate for compound 4 lay 4.0-fold (0.60 log units) below the measured number; measured number outside the range, above it.
By their numbers in this assay, from the lowest: compounds 3, 2 and 1 (each within the scatter of the next); then compound 4.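

In this assay, within the data shown here, the swap of 4-fluorophenyl for 2-chlorophenyl on the aromatic-ring nitrogen is the only step here beyond the scatter (a 4.3-fold higher number from compound 3 to compound 4 (0.63 log units; beyond the scatter)). The earlier change on this aryl group (a 1.2-fold lower number from compound 1 to compound 2 (0.09 log units; within the scatter)) stayed within the scatter, so this position does respond to what it carries. Nothing measured here accounts for the shift.

Compound 4 changes both the halogen and its place on the ring, leaving open which of the two carries the shift. A 2-fluorophenyl or a 4-chlorophenyl group on that nitrogen would separate them.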